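The source may hold more compounds than are shown below. What is called first, only, known or untested is meant among the compounds shown, and "the series" means these compounds.

Of the compounds shown here, two have so far been measured in an assay on isolated protein (urine) for inhibition of Myeloperoxidase (Homo sapiens), with a stated time of 5 min; on this read-out lower numbers stand for stronger inhibition and higher numbers for weaker inhibition. Compound 1, with the structure `N#CCCCc1c[nH]c2ccc(F)cc12`, gives 63 nM in this assay, the higher of the two numbers seen so far. Compound 2, with the structure `NCCCCc1c[nH]c2c(F)cccc12`, gives 6 nM in this assay, a clearly lower number, though the two compounds differ from each other in more than one place, so no single change can be tied to that gap.

Compound 3, with the structure `CNC(=O)CCCc1c[nH]c2ccc(F)cc12`, has not yet been measured. It differs from compound 1 in one place: methylcarbamoyl in place of cyano on a saturated chain carbon, three bonds along the chain from an aromatic carbon. Among the measured compounds shown here, no measured pair shows what this exchange does here, so the expectation for compound 3 rests on compound 1 alone. The step of a 1.3-fold higher number from compound 1 to compound 3 (0.10 log units; within the scatter) is expected to stay within the usual scatter, with no clear direction. Compound 3 is therefore estimated at 80 nM, in a range from 25 nM to 250 nM.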

Compound 3, half-maximal inhibitory concentration: 40 nM
For compound 3 the middle estimate is 2.0-fold (0.30 log units) above the measured one; low and high end bracket the measured number.
By their numbers in this assay, from the lowest: compound 2; then compounds 3 and 1 (each within the scatter of the next).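

On a saturated chain carbon, three bonds along the chain from an aromatic carbon, there is now one direct comparison in this assay: methylcarbamoyl in place of cyano gives a 1.6-fold lower number from compound 1 to compound 3 (0.20 log units; within the scatter) in this single pair. The exchange brings 4 heavy atoms in place of 2 and adds 1 hydrogen-bond donor, yet the two numbers stay within the usual scatter of each other. No measurement at hand says why the two groups read alike.

On these data alone, whether this tolerance extends to other groups remains open, since a carboxylic acid or a longer chain ending in methylcarbamoyl could behave quite differently at this place. Compound 2 differs from compound 3 in more than one place, so the compounds shown cannot tie its lower number to any single change.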